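A few compounds are considered here, and "the series" means these few. Any claim that something is new, unique, unknown or untested is made for them only; others in the source may bear on it.

Measured compounds:
Compound 1, `CC(C)=CC[C@@H](OC(=O)CCO)C1=CC(=O)c2c(O)ccc(O)c2C1=O`: 67600 nM
Compound 2, `CCCCC(O)CC(=O)O[C@H](CC=C(C)C)C1=CC(=O)c2c(O)ccc(O)c2C1=O`: 72200 nM
Compound 3, `CCCCC(CC(=O)O[C@H](CC=C(C)C)C1=CC(=O)c2c(O)ccc(O)c2C1=O)OC(C)=O`: 73500 nM

All three share one core and differ only in the acyl group joined through an oxygen to the chain carbon. In a functional assay on HeLa cells (Homo sapiens) for cytotoxicity, read by MTT assay (a higher number here means a weaker inhibitor, a lower number a stronger inhibitor), compound 1 gives the lowest of the three numbers, yet the gaps to its neighbours are small: a 1.1-fold higher number from compound 1 to compound 2 (0.03 log units; within the scatter) and a 1.1-fold higher number from compound 1 to compound 3 (0.04 log units; within the scatter), both within the scatter of repeated measurements. Likewise a 1.0-fold higher number from compound 2 to compound 3 (0.01 log units; within the scatter) shows that even a further change on that chain did not move the number.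

Compound 4, `CC(C)=CC[C@@H](OC(=O)C1CCOC1)C1=CC(=O)c2c(O)ccc(O)c2C1=O`, is the next member of the set. It differs from compound 1 as follows: oxolan-3-yl in place of 2-hydroxyethyl on a carbonyl carbon. This change sits on the same carbonyl carbon that was varied between compound 1, compound 2 and compound 3, and each of those variations left this assay unchanged beyond the scatter. Among the measured compounds shown here, the hydrogen-bond donor of the leaving group disappears, and a five-membered ring with one hetero atom enters, but nothing among the measured compounds shows that changes at this position alter cytotoxicity. The expected step is therefore none beyond the scatter, in either direction.

Compound 4 is expected to give about 70000 nM in this assay, with a likely range from 35000 nM to 140000 nM, which means an expected step of a 1.0-fold higher number from compound 1 to compound 4 (0.02 log units; within the scatter).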

Compound 4, half-maximal inhibitory concentration: 73500 nM
Compound 4: the middle estimate sits 1.1-fold (0.02 log units) below what was measured, within the range that was stated.
By their numbers in this assay, from the lowest: compounds 1, 2, 3 and 4 (each within the scatter of the next).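

In this assay, among the compounds shown here, replacing the open 2-hydroxyethyl with the ring-bearing oxolan-3-yl on this carbonyl carbon gives a 1.1-fold higher number from compound 1 to compound 4 (0.04 log units; within the scatter), so this position has now taken a five-membered non-aromatic ring, whereas the earlier compounds carried only open chains here. The ring compound also stays level with the two longer chains, with no change at the digits printed from compound 3 to compound 4 (within the scatter) for 2-acetoxyhexyl and a 1.0-fold higher number from compound 2 to compound 4 (0.01 log units; within the scatter) for 2-hydroxyhexyl, so across these four compounds neither chain length, nor the presence of a ring, nor the loss of the hydrogen-bond donor of compound 1 comes with a step beyond the scatter. No supporting data are available to explain this lack of change in the cell assay.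

On these data alone, all four groups on this carbonyl carbon are built only from carbon, hydrogen and oxygen, so it remains open whether an amine, a carboxylic acid or a phenyl ring at the same place would move the number. As far as these compounds go, what a change to the shared core would do also stays open, as the core is identical in all four compounds.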